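Kinetic solubility notes on the tricyclic amine series

The source may report more compounds than this note shows. Statements on the series, on what has been measured and on what is new or still open speak of the compounds shown alone.

Measured so far:
compound 1 `CN(C)S(=O)(=O)c1ccccc1Nc1cc(-c2ccc3ccn(C)c3c2)c2nccnc2c1`: 2 ug/mL
compound 2 `Cn1cc(NC(=O)c2ccncc2Nc2cc(-c3ccc4ccn(C)c4c3)c3nccnc3c2)cn1`: 2 ug/mL

In a physicochemical assay for solubility, read by spectrophotometry, measured as kinetic solubility, at pH 8, tested at 500 uM (on this read-out higher numbers stand for higher solubility and lower numbers for lower solubility), compound 1 gives 2 ug/mL and compound 2 gives 2 ug/mL; compound 2 stands level with compound 1 at the digits shown, the gap lying within the scatter. Compound 3 `CC(=O)N1CC(NC(=O)c2ccncc2Nc2cc(-c3ccc4ccn(C)c4c3)c3nccnc3c2)C1` is the next analogue and has not yet been measured. It differs from compound 2 in one place: 1-acetylazetidin-3-yl in place of 1-methyl-1H-pyrazol-4-yl on an amide-type nitrogen. For the measured compounds named here, no measured pair in this set shows a step of this kind, so the size must be guessed. A modest upward step from compound 2 to compound 3 is expected, a 4.0-fold higher number from compound 2 to compound 3 (0.60 log units; beyond the scatter), beyond the scatter but not large. Compound 3 is estimated at 8 ug/mL, with a range from 2 ug/mL to 30 ug/mL.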

Compound 3, solubility: 244 ug/mL
For compound 3 the middle estimate is 31-fold (1.48 log units) below the measured one; the whole stated range lies below it.
By their numbers in this assay, from the lowest: compounds 1 and 2 (each within the scatter of the next); then compound 3.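

In this assay, 1-acetylazetidin-3-yl in place of 1-methyl-1H-pyrazol-4-yl on an amide-type nitrogen gives a 120-fold higher number from compound 2 to compound 3 (2.09 log units; beyond the scatter), a large step. This position is therefore a place where a single change moves the read-out far beyond the scatter, which compound 1 and compound 2, level at the digits printed, gave no sign of.

Still open, going by these compounds, is whether the acetyl group or the four-membered non-aromatic ring carries the step, and whether a free amine or a carboxylic acid on this nitrogen's substituent would match it. Nothing available speaks to the origin of the step.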